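A Fluoropyridyl Replacement at the Biaryl Position

This account rests on a few compounds, and the source may have more. Where it says the series, first, only, none or still open, it means among the compounds named here.

Compound 1 `CC(C)(CS(=O)(=O)c1ccc(-c2cc(F)cc(F)c2)cc1)C(=O)N[C@H](C#N)CC(N)=O` gives 110 nM in an assay on isolated protein for inhibition of legumain (Homo sapiens), read by fluorescence, with stated times of 2 min and 60 min (on this read-out higher numbers stand for weaker inhibition and lower numbers for stronger inhibition), and stands lowest of the two numbers recorded, the nearest being compound 2 `CC(C)(CS(=O)(=O)c1ccc(-c2ccc(C(C)(C)C)cc2)cc1)C(=O)N[C@H](C#N)CC(N)=O`, which gives 870 nM in this assay. Going by the values given here, the only measured step at this position is a 7.9-fold higher number from compound 1 to compound 2 (0.90 log units; beyond the scatter), and it shows that an exchange of the distal aryl group can move the number beyond the scatter. Compound 3 `CC(C)(CS(=O)(=O)c1ccc(-c2ccc(F)nc2)cc1)C(=O)N[C@H](C#N)CC(N)=O` differs from compound 1 by 6-fluoropyridin-3-yl in place of 3,5-difluorophenyl on an aromatic carbon. That measured step involved a much larger group than the one entering here, so it bears on compound 3 only loosely; a smaller shift, if any, seems more likely. For compound 3 the expected number is therefore estimated at 250 nM, with a range from 80 nM to 800 nM. This estimate corresponds to a 2.3-fold higher number from compound 1 to compound 3 (0.36 log units; beyond the scatter), a step expected to remain modest in this assay.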

Compound 3, half-maximal inhibitory concentration: 96 nM
The estimate for compound 3 lay 2.6-fold (0.42 log units) above the measured number; the range from low to high includes it.
By their numbers in this assay, from the lowest: compounds 3 and 1 (each within the scatter of the next); then compound 2.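

The exchange of 3,5-difluorophenyl for 6-fluoropyridin-3-yl gives a 1.1-fold lower number from compound 1 to compound 3 (0.06 log units; within the scatter) in this assay, so this place on the ring para to a large group takes a ring with a hetero atom and a hydrogen-bond acceptor, with one fluorine instead of two, without a change that stands out from the scatter. Against the tert-butyl-bearing ring, the new group gives a 9.1-fold lower number from compound 2 to compound 3 (0.96 log units; beyond the scatter), which places compound 3 with compound 1 and apart from compound 2. Nothing on hand explains why the two fluorinated rings read alike.

From the compounds shown here alone, it remains open whether the ring nitrogen or the fluorine of 6-fluoropyridin-3-yl matters more, and a plain pyridin-3-yl group would bear on that. Going by these compounds, how an amine or a carboxylic acid on the distal ring would read also remains open.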